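Dichlorophenyl in place of phenyl: efficacy notes

The source may hold more compounds than are shown below. What is called first, only, known or untested is meant among the compounds shown, and "the series" means these compounds.

Measured so far:
compound 1, `c1ccc(C(CCC/N=C(/NCCCc2c[nH]cn2)NC2CCCCC2)c2ccccn2)cc1`, 0.25
compound 2, `CN/C(=N\CCC(c1ccc(Br)cc1)c1ccccn1)NCCCc1c[nH]cn1`, 0.9

In an assay on cardiac atrium with histamine H2 receptor (Cavia porcellus) as the target (on this read-out lower numbers stand for smaller maximal responses and higher numbers for larger maximal responses), compound 1 gives 0.25, the lower of the two numbers obtained; compound 2 gives 0.9, a value a good deal higher and beyond the usual scatter. Compound 2 differs from compound 1 in more than one place, so the two values show only that the series spans a wide range of maximal response; they do not isolate any single change.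

Compound 3, `Clc1ccc(C(CCC/N=C(/NCCCc2c[nH]cn2)NC2CCCCC2)c2ccccn2)cc1Cl`, has not yet been measured. It differs from compound 1 in one place: 3,4-dichlorophenyl in place of phenyl on a saturated chain carbon bound to an aromatic carbon and a saturated chain carbon. Going by the values given here, no measured pair shows this change, so the size of the step is unknown. Given the low starting point of compound 1 at 0.25 and the high value reached by compound 2, a modest rise is expected for compound 3, but a step within the scatter is also plausible; the expected step is a number 0.15 higher from compound 1 to compound 3 (beyond the scatter). For compound 3 the estimated intrinsic activity is 0.4, within a range from 0.15 to 0.7.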

Compound 3, intrinsic activity: the largest response reached, as a fraction of the reference agonist's: 1
For compound 3 the middle estimate is 0.60 below the measured one, outside the stated range (above it).
By their numbers in this assay, from the lowest: compound 1; then compounds 2 and 3 (each within the scatter of the next).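

In this assay, going by these compounds alone, 3,4-dichlorophenyl in place of phenyl on a saturated chain carbon bound to an aromatic carbon and a saturated chain carbon gives a number 0.75 higher from compound 1 to compound 3 (beyond the scatter), the first step that can be tied to a single place. This position therefore has a large bearing on maximal response, even though the change only takes the group from 6 to 8 heavy atoms, both of them chlorine, with 0 hydrogen-bond donors, 0 hydrogen-bond acceptors and no net charge on either side. No measurement shown here accounts for the size of the step.

The compounds shown do not separate the two chlorines, so it remains open whether a phenyl carrying one chlorine, or one carrying methoxy or trifluoromethyl instead, would give a step of similar size. From the compounds shown here alone, the step is also read on the core of compound 1 alone, and whether it carries over to a core with a methyl group in place of the other substituent on that end of the molecule stays unknown.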